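The compounds below may be only part of what the source reports. "The series", "measured", "known", "first", "only" and "open" are said of these compounds alone.

Measured so far:
- Compound 1, `O=C1/C(=C/c2ccc(O)c(O)c2)SC(=S)N1c1ccc(O)cc1`: in an assay on cells for inhibition of HSP60/HSP10 (Homo sapiens), read by malachite green (a higher number here means a weaker inhibitor, a lower number a stronger inhibitor), compound 1 gives > 250000 nM, which is a limit of the assay rather than a number.
- Compound 2, `CNC(=O)Nc1ccc2nc(-c3ccco3)c(-c3ccco3)nc2c1`: in this assay compound 2 gives > 250000 nM, again only a limit.
- Compound 3, `Nc1ccc(Nc2nc(-c3ccc(O)c(O)c3)cs2)cc1`: in this assay compound 3 gives > 250000 nM, also a limit.

Compound 2 therefore stands nowhere in particular among these three: all of them sit at the limit of > 250000 nM in this assay, at which 3 of the 3 values shown sit, so no ordering by strength is possible, and none of them can be called stronger or weaker than another. In plain terms, none of the three showed measurable inhibition within the tested range.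

Compound 4, `O=C(Nc1ccc2nc(-c3ccco3)c(-c3ccco3)nc2c1)N1CCCC1`, is compound 2 with one change, pyrrolidin-1-yl in place of methylamino on a carbonyl carbon. Between the measured compounds no pair differing in one place exists, so the data give no measured step to lean on for this kind of change.

With compound 2 at a limit, the expected step from compound 2 to compound 4 in this assay is estimated as none beyond the scatter, a step that the limit leaves unreadable from compound 2 to compound 4. Compound 4 is expected to give about 300000 nM in this assay, with a range from 80000 nM to 2000000 nM, and most likely to be reported again only as a limit.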

Compound 4, half-maximal inhibitory concentration: > 250000 nM
Compound 4 gave a limit, no number (the forecaster's own chance of this, stated with the estimate: 85%); the middle value does not contradict the limit.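

Compound 2 and compound 4 both gave only a limit, not a number, so no step can be read for pyrrolidin-1-yl in place of methylamino on a carbonyl carbon. All four compounds share that result: the limit of > 250000 nM in this assay, at which 4 of the 4 values shown sit.

The compounds shown leave open which structure, if any, would give an actual number in this assay.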